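The source may hold more compounds than are shown below. What is called first, only, known or untested is meant among the compounds shown, and "the series" means these compounds.

Working notes on the series

Compound 1 `COc1ccc(-c2cc(/C=C/C(=O)c3ccc(N)cc3)[nH]n2)cc1` is measured in a functional assay on NCI-H226 cells (Homo sapiens) for cytotoxicity, read by sulforhodamine B assay, with a stated time of 48 h, tested at 0.01 uM (a lower number here means a stronger effect, a higher number a weaker effect of the compound at the concentration tested), and gives 102%. Compound 2 `COc1ccc(C(=O)/C=C/c2cc(-c3cc(OC)c(OC)c(OC)c3)n[nH]2)cc1OC` gives 98% in this assay, and compound 3 `COc1cc(-c2cc(/C=C/C(=O)c3ccc(F)c(F)c3)[nH]n2)cc(OC)c1OC` gives 99%. Compound 1 has the largest of the three numbers, but its gaps to compound 3 and to compound 2 both fall within the scatter, so the three compounds cannot be told apart on these data.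

Compound 4 `COc1ccc(-c2cc(/C=C/C(=O)c3ccc(N)cc3)[nH]n2)cc1OC` is not yet measured in this assay. It differs from compound 1 by methoxy in place of hydrogen on an aromatic carbon. Within the data shown here, no measured pair changes this position of the shared core. Among the measured compounds shown here, the only measured step, a swap on the carbonyl carbon, moved the number by a number 1 percentage points higher from compound 2 to compound 3 (within the scatter), and every measured value in this set sits within the scatter of every other. On that basis the change from compound 1 to compound 4 is expected to give no step beyond the scatter, a step of a number 2 percentage points lower from compound 1 to compound 4 (within the scatter). Compound 4 is therefore estimated at 100%, in a range from 90% to 110%.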

Compound 4, a percentage reported as activity, at one concentration (the size of the read-out at that concentration, not a potency): 93%
Compound 4: middle estimate off by 7 percentage points, on the high side; the range from low to high includes it.
By their numbers in this assay, from the lowest: compounds 4, 2, 3 and 1 (each within the scatter of the next).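

Methoxy in place of hydrogen on this aromatic carbon, ortho to a methoxy group and meta to a large group, gives a number 9 percentage points lower from compound 1 to compound 4 (within the scatter) in this assay. Among these compounds, this is the first measured pair that changes this position of the shared core, and the step does not separate the two compounds at the single concentration tested. Nothing available explains the size of this step.

Going by these compounds, whether a fluorine atom, a hydroxy group or a longer alkoxy chain on the same carbon would give a step beyond the scatter remains open. Also open, on these data alone, are whether the methoxy step would stay the same with 3,4-difluorophenyl on the carbonyl carbon in place of the aminophenyl group, and whether compound 1 and compound 4 would separate at another concentration.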